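From Cyclopropyl to Cyclobutyl on the Shared Core

A few compounds are considered here, and "the series" means these few. Any claim that something is new, unique, unknown or untested is made for them only; others in the source may bear on it.

Of the compounds shown here, three that share one core have been tested in a functional assay on the whole organism (plasma, strain Sprague-Dawley) with Rattus norvegicus as the target, with a stated time of 2 h, at a dose of 100 mg/kg by the oral route; a lower number here means a weaker effect, a higher number a stronger effect of the compound at the dose given. Compound 1 `c1ccc(C(/N=C2\CCCCCN2)C2CC2)cc1` gives 51%, the highest of the three numbers. Compound 2 `COc1ccc(C(/N=C2\CCCCCN2)C2CC2)cc1` gives 40%, and compound 3 `c1ccc2c(C(/N=C3\CCCCCN3)C3CC3)cccc2c1` gives 21%. Going by the values given here, the only step measured between compounds that differ in one place is a number 11 percentage points lower from compound 1 to compound 2 (beyond the scatter), where a methoxy replaces a hydrogen on an aromatic carbon. Compound 4 `c1ccc(C(/N=C2\CCCCCN2)C2CCC2)cc1` has not yet been measured in this assay. It differs from compound 1 in one place: cyclobutyl in place of cyclopropyl on a saturated chain carbon bound to an aromatic carbon and a double-bonded nitrogen. Among the compounds with values here, no measured step concerns the saturated ring on that chain carbon; the step from compound 1 to compound 2 alters the aromatic ring, and for compound 3 no single-place step to compound 1 is available, so the data hold nothing that bears directly on this change. Without a guiding step, the expected change is a step of a number 4 percentage points lower from compound 1 to compound 4 (within the scatter), not beyond the scatter. Compound 4 is therefore estimated at 47%, within a range from 30% to 64%.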

Compound 4, a percentage reported as inhibition, in the whole organism at one dose (the size of the read-out at that dose, not a potency): 44%
Beside the measured number, compound 4's estimate is 3 percentage points above it, within the range that was stated.
By their numbers in this assay, from the lowest: compound 3; then compounds 2, 4 and 1 (each within the scatter of the next, the first and the last beyond it).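

Cyclobutyl in place of cyclopropyl, on a saturated chain carbon bound to an aromatic carbon and a double-bonded nitrogen, gives a number 7 percentage points lower from compound 1 to compound 4 (within the scatter) in this assay. Going by these compounds alone, this is the first view of the saturated ring at this position, as the earlier step concerned the aromatic ring. In this read-out at a single dose, the three-membered and four-membered rings cannot be told apart, and nothing available gives a reason for this result.

From the compounds shown here alone, whether the same tolerance would hold for cyclopentyl, for an open chain such as isopropyl, or for a ring carrying an amine remains open. Also open, going by these compounds, is whether cyclobutyl would give a similar result alongside the methoxy group of compound 2 or on the core of compound 3.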